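The source may hold more compounds than are shown below. What is called first, only, known or untested is meant among the compounds shown, and "the series" means these compounds.

Measured in a functional assay on a cell-free system (plasma) for inhibition of thromboxane A2 receptor (Homo sapiens), read by turbidimetry (a lower number here means a stronger inhibitor, a higher number a weaker inhibitor), compound 1 `O=C(O)COCCCC[C@H]1[C@H](F)CC[C@@H]1NS(=O)(=O)c1ccc(F)cc1F` gives 1800 nM. Compound 2 `O=C(O)CC/C=C\C[C@H]1[C@H](F)CC[C@@H]1NS(=O)(=O)c1ccc(Cl)c(Cl)c1` gives 1700 nM. Compound 3 `O=C(O)COCCCCC1=CCC[C@@H]1CNS(=O)(=O)c1ccc(F)cc1` gives 200 nM.

Compound 2 holds the second-highest number of the three. Compound 1 stands nearest, within the scatter, so no order between those two is claimed. Compound 3 gives a clearly lower number, beyond the scatter, but it differs from compound 2 in more than one place. Compound 4 `O=C(O)CC/C=C\C[C@H]1[C@H](F)CC[C@@H]1NS(=O)(=O)c1ccc(F)cc1` arises from compound 2 by 4-fluorophenyl in place of 3,4-dichlorophenyl on a sulfonyl sulfur. Within the data shown here, no measured pair isolates this change, and compound 3, which also carries a 4-fluorophenyl, rests on a different core. In this assay a modest step toward a lower number is expected, or none beyond the scatter: a 1.4-fold lower number from compound 2 to compound 4 (0.15 log units; within the scatter). Compound 4 is estimated at 1200 nM, between 400 nM and 3500 nM.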

Compound 4, half-maximal inhibitory concentration: 750 nM
Estimate against measurement, compound 4: 1.6-fold (0.20 log units) above; the range from low to high includes it.
By their numbers in this assay, from the lowest: compound 3; then compound 4; then compounds 2 and 1 (each within the scatter of the next).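

On a sulfonyl sulfur whose other neighbour is the sulfonamide nitrogen, 4-fluorophenyl in place of 3,4-dichlorophenyl gives a 2.3-fold lower number from compound 2 to compound 4 (0.36 log units; beyond the scatter) in this assay. Among these compounds, this is the first single-place comparison here, and it shows that the aryl group at this position alters the number on this core, modestly but beyond the scatter. Nothing at hand explains the step.

The compounds shown leave open whether removing the chlorines or adding the fluorine accounts for it. A 4-chlorophenyl or an unsubstituted phenyl at this position would help separate the two.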